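Tetrazole for imidazole on the dioxolane side chain

The source may report more compounds than this note shows. Statements on the series, on what has been measured and on what is new or still open speak of the compounds shown alone.

Compound 1 `CCC(C)n1ncn(-c2ccc(N3CCN(c4ccc(OC[C@@H]5CO[C@@](Cn6ccnc6)(c6ccc(Cl)cc6Cl)O5)cn4)CC3)cc2)c1=O` is the reference point for this set. In a physicochemical assay for solubility, read by HPLC, measured as thermodynamic solubility (on this read-out higher numbers stand for higher solubility and lower numbers for lower solubility), compound 1 gives 2.94 ug/mL. Compound 3 `CCC(C)n1ncn(-c2ccc(N3CCN(c4ccc(OC[C@@H]5CO[C@@](Cn6cnnn6)(c6ccc(Cl)cc6Cl)O5)cn4)CC3)cc2)c1=O` carries the change (1H-tetrazol-1-yl in place of 1H-imidazol-1-yl on a saturated chain carbon bound to a saturated ring carbon), and in this assay compound 3 gives 0.951 ug/mL; the step is a 3.1-fold lower number from compound 1 to compound 3 (0.49 log units; beyond the scatter).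

Compound 2 `CCC(C)n1ncn(-c2ccc(N3CCN(c4ccc(OC[C@@H]5CO[C@@](Cn6ccnc6)(c6ccc(Cl)cc6Cl)O5)cc4)CC3)c(F)c2)c1=O` rests on a different core; how that core differs from the core of compound 1 is not broken down here. In this assay compound 2 gives 17.2 ug/mL, the highest number of the three measured compounds, with compound 1 nearest and compound 3 furthest from it, both beyond the scatter.

Compound 4 `CCC(C)n1ncn(-c2ccc(N3CCN(c4ccc(OC[C@@H]5CO[C@@](Cn6cnnn6)(c6ccc(Cl)cc6Cl)O5)cc4)CC3)c(F)c2)c1=O` is not yet measured. It stands to compound 2 as compound 3 stands to compound 1, through the change (1H-tetrazol-1-yl in place of 1H-imidazol-1-yl on a saturated chain carbon bound to a saturated ring carbon); the place is the same in both pairs, so it is the same change, made the second time in the set. For the measured compounds named here, the only measured instance of this change is the step from compound 1 to compound 3, and the expectation for compound 4 rests on that single pair. The step from compound 2 to compound 4 is expected to be about a 3.1-fold lower number from compound 2 to compound 4 (0.50 log units; beyond the scatter), set beside a 3.1-fold lower number from compound 1 to compound 3 (0.49 log units; beyond the scatter), on the assumption that the change carries over from one core to the other. Compound 4 is therefore estimated at 5.5 ug/mL, most likely between 2.5 ug/mL and 12 ug/mL.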

Compound 4, solubility: 0.0528 ug/mL
For compound 4 the middle estimate is 100-fold (2.02 log units) above the measured one; the measured number lies below the stated range.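

Read in this assay, the change of 1H-imidazol-1-yl to 1H-tetrazol-1-yl on a saturated chain carbon bound to a saturated ring carbon gives a 330-fold lower number from compound 2 to compound 4 (2.51 log units; beyond the scatter) on the core of compound 2, set against a 3.1-fold lower number from compound 1 to compound 3 (0.49 log units; beyond the scatter) on the core of compound 1, so both pairs move the same way but the step is much larger on the core of compound 2. The size of this step therefore does not carry from one core to the other in this series, and one pair cannot be used to size the change on another core, although two pairs are too few to say how the step depends on the core in general. The difference between the two cores is not broken down here, and nothing shown ties the larger step to any particular part of that difference or offers a reason for it.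

A triazole or a simple amine on the same saturated chain carbon would show whether the large step on the core of compound 2 is particular to 1H-tetrazol-1-yl or appears with other groups there. A third core carrying the same pair of groups would show which of the two steps is the more usual one.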